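Swapping a dichlorophenyl for a dimethoxyphenyl on the ketone

The source may hold more compounds than are shown below. What is called first, only, known or untested is meant among the compounds shown, and "the series" means these compounds.

Of the compounds shown here, three sharing one core have been measured in a functional assay on MDA-MB-231 cells (Homo sapiens) for inhibition, read by MTT assay, with a stated time of 48 h; on this read-out lower numbers stand for stronger inhibition and higher numbers for weaker inhibition. Compound 1 `COc1cc(-c2cc(/C=C/C(=O)c3ccc(Cl)c(Cl)c3)[nH]n2)cc(OC)c1OC` gives 2100 nM. Compound 2 `COc1ccc(-c2cc(/C=C/C(=O)c3cc(OC)c(OC)c(OC)c3)[nH]n2)cc1` gives 2400 nM, and compound 3 `COc1ccc(-c2cc(/C=C/C(=O)c3ccc(N)cc3)[nH]n2)cc1` gives 1700 nM. The number for compound 1 sits close to both of the others, and every gap among the three lies within the usual scatter of such measurements, so none of them can be called more or less potent than another.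

Compound 4 `COc1ccc(C(=O)/C=C/c2cc(-c3cc(OC)c(OC)c(OC)c3)n[nH]2)cc1OC` has not been measured. It differs from compound 1 in one place: 3,4-dimethoxyphenyl in place of 3,4-dichlorophenyl on a carbonyl carbon. Going by the values given here, no measured pair shows exactly this exchange, so the expectation rests on the three numbers above, which cluster tightly despite different groups on the carbonyl carbon. The step from compound 1 to compound 4 is therefore expected to be small, a 1.2-fold higher number from compound 1 to compound 4 (0.08 log units; within the scatter), likely no larger than the scatter itself, in either direction. In this assay compound 4 is estimated to give 2500 nM, with a plausible range from 1000 nM to 6000 nM.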

Compound 4, half-maximal inhibitory concentration: 620 nM
Beside the measured number, compound 4's estimate is 4.0-fold (0.61 log units) above it; the measured number lies below the stated range.
By their numbers in this assay, from the lowest: compound 4; then compounds 3, 1 and 2 (each within the scatter of the next).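

Going by these compounds alone, putting 3,4-dimethoxyphenyl in place of 3,4-dichlorophenyl on a carbonyl carbon gives, in this assay, a 3.4-fold lower number from compound 1 to compound 4 (0.53 log units; beyond the scatter), and this is the first single-place change that can be read as a step. It is modest but beyond the scatter, and the rest of the molecule stays the same, so the group on this carbonyl carbon can shift the number on its own, with the lower number going to the dimethoxy group. Nothing available explains why this exchange has this effect.

Only these two groups can be compared on an otherwise unchanged molecule, so the result does not tell whether both methoxy groups are needed. Nor does it tell how a 3,4-dihydroxyphenyl, a 3,4-difluorophenyl or a single methoxy group would compare at this position.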